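Halogen swap on the benzoyl ring of a dinitrophenyl ether chalcone

This account rests on a few compounds, and the source may have more. Where it says the series, first, only, none or still open, it means among the compounds named here.

Compound 3 `O=C(/C=C/c1cc(Cl)cc(Cl)c1Oc1c([N+](=O)[O-])cc(C(F)(F)F)cc1[N+](=O)[O-])c1ccc(Cl)cc1` and compound 4 `O=C(/C=C/c1cc(Cl)cc(Cl)c1Oc1c([N+](=O)[O-])cc(C(F)(F)F)cc1[N+](=O)[O-])c1ccc(Br)cc1` share a core whose difference from compound 2 `Cc1ccc(C(=O)/C=C/c2cccc(Cl)c2Oc2c([N+](=O)[O-])cc(C(F)(F)F)cc2[N+](=O)[O-])cc1` is not broken down here. In a functional assay on A549 cells (Homo sapiens) for antiproliferative activity, read by MTT assay, with a stated time of 48 h (on this read-out higher numbers stand for weaker inhibition and lower numbers for stronger inhibition), compound 2 gives 0.95 ug/mL, while compound 3 gives 17.2 ug/mL, the highest of the three measured numbers. Compound 1 `Cc1ccc(C(=O)/C=C/c2cccc(Br)c2Oc2c([N+](=O)[O-])cc(C(F)(F)F)cc2[N+](=O)[O-])cc1` gives 6.85 ug/mL in this assay. The change from compound 2 to compound 1 is bromo in place of chloro on an aromatic carbon; it made a 7.2-fold higher number from compound 2 to compound 1 (0.86 log units; beyond the scatter). Compound 4 carries the same kind of change, (bromo in place of chloro on an aromatic carbon), but the place differs: in compound 1 the bromo sits ortho to a large group and meta to a 2-((4-methylphenyl)carbonyl)ethenyl group, whereas in compound 4 it sits para to a large group. Resting on the earlier step, weaker inhibition is expected for compound 4, a step of a 1.6-fold higher number from compound 3 to compound 4 (0.21 log units; within the scatter), kept smaller than the earlier one since the surroundings differ. Compound 4 is therefore estimated at 28 ug/mL, within 9 ug/mL to 85 ug/mL.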

Compound 4, half-maximal inhibitory concentration: 14.5 ug/mL
Beside the measured number, compound 4's estimate is 1.9-fold (0.29 log units) above it, within the range that was stated.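

In this assay, bromo in place of chloro did not carry over from one core to the other. On the core of compound 3 it gave a 1.2-fold lower number from compound 3 to compound 4 (0.07 log units; within the scatter), and the two steps do not agree: the same change on two cores in this assay, a 7.2-fold higher number (0.86 log units; beyond the scatter) from compound 2 to compound 1 and a 1.2-fold lower number (0.07 log units; within the scatter) from compound 3 to compound 4, 8.6-fold (0.93 log units) apart, beyond the scatter of two such steps

The two pairs differ both in where the swap sits and in the rest of the core, so they do not show which of these accounts for the gap, and two pairs give no general rule for the series.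

The compounds shown leave open how an amine or a carboxylic acid would compare in place of the bromo of the 4-bromophenyl group of compound 4.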